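The source may hold more compounds than are shown below. What is called first, only, known or untested is meant among the compounds shown, and "the series" means these compounds.

Compound 1 `Cc1cc(F)cnc1N1CCN(C(=O)CCCc2cccc3ncoc23)[C@@H](C)C1`, compound 2 `Cc1cc(F)cnc1N1CCN(C(=O)CCCc2cccc3ncccc23)[C@@H](C)C1` and compound 3 `Cc1cc(F)cnc1N1CCN(C(=O)CCCc2cccc3ncsc23)[C@@H](C)C1` share one core and differ only in the aromatic group on the chain. In an ADME assay on microsomes from liver (Rattus norvegicus) for metabolic stability, read by LC-MS, with a stated time of 15 min, tested at 1 uM (on this read-out lower numbers stand for a less stable compound and higher numbers for a more stable compound), compound 1 gives 0%, compound 2 gives 0.2% and compound 3 gives 5.3%, the highest of the three numbers, though the steps of a number 5.3 percentage points higher from compound 1 to compound 3 (within the scatter) and a number 5.1 percentage points higher from compound 2 to compound 3 (within the scatter) both stay within the scatter, as does a number 0.2 percentage points higher from compound 1 to compound 2 (within the scatter). Compound 4 `Cc1cc(F)cnc1N1CCN(C(=O)CCCc2cccc3nc(N)sc23)[C@@H](C)C1` carries the change (amino in place of hydrogen on an aromatic carbon). For the measured compounds named here, no measured step covers an amino entering on an aromatic carbon; the ring swaps so far moved this assay by little, so no step beyond the scatter is expected here. For compound 4 the expected value in this assay is 8%, with a range of 0% to 25%, the expected step being a number 2.7 percentage points higher from compound 3 to compound 4 (within the scatter).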

Compound 4, percent of the compound remaining: 3.7%
Beside the measured number, compound 4's estimate is 4.3 percentage points above it; measured number inside the range.
By their numbers in this assay, from the lowest: compounds 1, 2, 4 and 3 (each within the scatter of the next).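

In this assay, amino in place of hydrogen on the aromatic carbon next to the ring nitrogen and next to the ring sulfur gives a number 1.6 percentage points lower from compound 3 to compound 4 (within the scatter), so this new position and change add no step beyond the scatter. Against the other two aromatic groups, the 2-amino-1,3-benzothiazol-7-yl group gives a number 3.5 percentage points higher from compound 2 to compound 4 (within the scatter) and a number 3.7 percentage points higher from compound 1 to compound 4 (within the scatter). No available evidence bears on this result. Open, from the compounds shown here alone, is whether a dimethylamino or methyl group on the same carbon, or a shorter chain to the carbonyl, would give a step beyond the scatter.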